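The compounds below may be only part of what the source reports. "The series", "measured", "known", "first", "only" and "open" are said of these compounds alone.

Compound 1 `CNS(=O)(=O)NC[C@@H]1CCCc2cc(S(=O)(=O)c3cccc(F)c3)ccc21` and compound 2 `CN(C)S(=O)(=O)NC[C@@H]1CCCc2cc(S(=O)(=O)c3cccc(F)c3)ccc21` share one core and differ only by methyl in place of hydrogen on a sulfonamide nitrogen. In an assay on isolated protein for displacement of a labelled ligand from 5-hydroxytryptamine receptor 6 (Homo sapiens) (a higher number here means a weaker inhibitor, a lower number a stronger inhibitor), compound 1 gives 1 nM, while compound 2 gives 2 nM, a step that is a 2.0-fold higher number from compound 1 to compound 2 (0.30 log units; within the scatter). Compound 3 `NCC(=O)NC[C@@H]1CCCc2cc(S(=O)(=O)c3cccc(F)c3)ccc21` keeps the same core but carries another group, the difference being ((aminomethyl)carbonyl in place of methylsulfamoyl on an amine nitrogen); in this assay compound 3 gives 0.316 nM. Compound 4 `CNCC(=O)NC[C@@H]1CCCc2cc(S(=O)(=O)c3cccc(F)c3)ccc21` has not yet been measured and differs from compound 3 by methyl in place of hydrogen on an amine nitrogen. Within the data shown here, this is the same kind of change as the one from compound 1 to compound 2, but not the same: there the methyl enters on a sulfonamide nitrogen whose other neighbours are a saturated chain carbon and a sulfonyl sulfur, here on an amine nitrogen whose only other neighbour is a saturated chain carbon. For compound 4 a small step of a 1.6-fold higher number from compound 3 to compound 4 (0.20 log units; within the scatter) is expected, resting on the earlier step of a 2.0-fold higher number from compound 1 to compound 2 (0.30 log units; within the scatter), which stayed within the scatter. Compound 4 is accordingly estimated at 0.5 nM, with a likely range from 0.15 nM to 1.6 nM.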

Compound 4, inhibition constant: 0.159 nM
Estimate against measurement, compound 4: 3.1-fold (0.50 log units) above, within the range that was stated.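

In this assay the methyl on the amine nitrogen gives a 2.0-fold lower number from compound 3 to compound 4 (0.30 log units; within the scatter), while replacing the sulfamoyl groups with ((methylamino)methyl)carbonyl gives a 6.3-fold lower number from compound 1 to compound 4 (0.80 log units; beyond the scatter) and a 13-fold lower number from compound 2 to compound 4 (1.10 log units; beyond the scatter). The methyl change does not carry over unchanged from the core of compound 1 to that of compound 3: the same change on two cores in this assay, a 2.0-fold higher number (0.30 log units; within the scatter) from compound 1 to compound 2 and a 2.0-fold lower number (0.30 log units; within the scatter) from compound 3 to compound 4, 4.0-fold (0.60 log units) apart, beyond the scatter of two such steps. Yet each step alone lies within the scatter, and with only one pair on each core, this gap shows neither why the steps differ nor how the change would behave on any further core. The compounds shown leave open what a second methyl, giving a dimethylamino group, would do on that amine nitrogen. On these data alone, an ethyl or a cyclopropyl group there is equally open.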